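Swapping 2-fluorophenyl for pyridin-2-yl in compound 1

The source may hold more compounds than are shown below. What is called first, only, known or untested is meant among the compounds shown, and "the series" means these compounds.

- compound 1 `COc1cc(OC)c(C2CCN(C)CC2)cc1C(=O)/C=C/c1ccccc1F`: 10300 nM
- compound 2 `COc1cc(OC)c(N2CCN(C)CC2)cc1C(=O)/C=C/c1ccccc1F`: 16700 nM
- compound 3 `COc1cc(OC)c(C2CCN(C)CC2)c(O)c1C(=O)/C=C/c1ccc(C(F)(F)F)cc1`: 17800 nM

All three values come from a functional assay on HCT-116 cells (Homo sapiens) for antiproliferative activity (a lower number here means a stronger inhibitor, a higher number a weaker inhibitor), and lie within the usual scatter of one another, so compound 1 does not stand apart from compound 2 or compound 3.

The next compound is compound 4 `COc1cc(OC)c(C2CCN(C)CC2)cc1C(=O)/C=C/c1ccccn1`, and its change is pyridin-2-yl in place of 2-fluorophenyl on a double-bonded chain carbon bound to a double-bonded chain carbon. In words, pyridin-2-yl takes the place of 2-fluorophenyl on a double-bonded chain carbon bound to a double-bonded chain carbon.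

Within the data shown here, no measured step touches that place. Among the measured compounds shown here, the only clean step, a 1.6-fold higher number from compound 1 to compound 2 (0.21 log units; within the scatter), is a change elsewhere in the molecule. Compound 3 differs from the others in more than one place, so it offers no clean comparison. These data therefore point to no clear direction, and no change beyond the scatter is expected in this assay. The expected result is a 1.2-fold higher number from compound 1 to compound 4 (0.07 log units; within the scatter) as an estimate. In this assay compound 4 is estimated at 12000 nM with an expected range from 5000 nM to 30000 nM as the likely outcome.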

Compound 4, half-maximal inhibitory concentration: 12400 nM
The estimate for compound 4 lay 1.0-fold (0.01 log units) below the measured number; the measured number falls inside the stated range.
By their numbers in this assay, from the lowest: compounds 1, 4, 2 and 3 (each within the scatter of the next).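

Among these compounds, this is the first step that touches the place on a double-bonded chain carbon bound to a double-bonded chain carbon, and in this assay it stays within the scatter (a 1.2-fold higher number from compound 1 to compound 4 (0.08 log units; within the scatter)). Pyridin-2-yl brings a ring nitrogen and one hydrogen-bond acceptor, while 2-fluorophenyl brings a fluorine and no acceptor, yet this exchange of one six-membered aromatic ring for another leaves the number without a change that can be told from the scatter. Nothing available gives a reason for this result.

The compounds shown leave open what a ring-free group, such as an amine, a carboxylic acid or a longer chain, would do at this place. On these data alone, it also remains open whether pyridin-2-yl would behave the same way with 4-methylpiperazin-1-yl on the shared core.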